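Swapping 2-bromophenyl for 2-chloropyridin-3-yl

This account rests on a few compounds, and the source may have more. Where it says the series, first, only, none or still open, it means among the compounds named here.

Measured in a functional assay on A549 cells (Homo sapiens) for antiproliferative activity, read by MTT assay; on this read-out higher numbers stand for weaker inhibition and lower numbers for stronger inhibition:
- compound 1 `COc1ccc(/C=C2/SC(N3CCC[C@H]3C(=O)Nc3ccc4ncnc(Nc5cccc(Cl)c5)c4c3)=NC2=O)cc1`: 31700 nM
- compound 2 `O=C1N=C(N2CCC[C@H]2C(=O)Nc2ccc3ncnc(Nc4cccc(Cl)c4)c3c2)S/C1=C/c1cccnc1`: 10400 nM
- compound 3 `O=C1N=C(N2CCC[C@H]2C(=O)Nc2ccc3ncnc(Nc4cccc(Cl)c4)c3c2)S/C1=C/c1ccccc1Br`: > 50000 nM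

Compound 3 is known only by a limit, > 50000 nM. Compound 4 `O=C1N=C(N2CCC[C@H]2C(=O)Nc2ccc3ncnc(Nc4cccc(Cl)c4)c3c2)S/C1=C/c1cccnc1Cl` differs from it on a double-bonded chain carbon bound to a double-bonded ring carbon: 2-chloropyridin-3-yl in place of 2-bromophenyl on a double-bonded chain carbon bound to a double-bonded ring carbon. Among the compounds with values here, two measured steps bear on this change. The step to pyridin-3-yl was a 3.0-fold lower number from compound 1 to compound 2 (0.48 log units; beyond the scatter), and the step to 2-bromophenyl was an at least 4.8-fold higher number from compound 2 to compound 3 (0.68 log units; beyond the scatter). The entering group shares a ring hetero atom with compound 2 and a halogen with compound 3, so a value between those two compounds is expected. The expected size and direction are an at least 2.5-fold lower number from compound 3 to compound 4 (0.39 log units; beyond the scatter). Compound 4 is estimated at 20000 nM, with an expected range from 7000 nM to 50000 nM.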

Compound 4, half-maximal inhibitory concentration: 10800 nM
The estimate for compound 4 lay 1.9-fold (0.27 log units) above the measured number; measured number inside the range.
By their numbers in this assay, from the lowest: compounds 2 and 4 (each within the scatter of the next); then compound 1. At a limit, above all of these: compound 3.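

In this assay, 2-chloropyridin-3-yl in place of 2-bromophenyl gives an at least 4.6-fold lower number from compound 3 to compound 4 (0.66 log units; beyond the scatter), so a halogen on this ring does not by itself go with the loss seen in compound 3. Chloro in place of hydrogen on an aromatic carbon gives a 1.0-fold higher number from compound 2 to compound 4 (0.02 log units; within the scatter), and 2-chloropyridin-3-yl in place of 4-methoxyphenyl gives a 2.9-fold lower number from compound 1 to compound 4 (0.47 log units; beyond the scatter). Compound 3 is known only by a limit: the limit of > 50000 nM in this assay, at which 1 of the 4 values shown sits.

The compounds shown leave open whether the ring nitrogen or the change of halogen carries the step, which a 2-chlorophenyl group would help to separate. From the compounds shown here alone, how an amine at this place would read also remains open.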